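The source may report more compounds than this note shows. Statements on the series, on what has been measured and on what is new or still open speak of the compounds shown alone.

Measured so far:
compound 1, `COc1ccc(-c2ccc(C(C)O[C@H]3C[C@@H](N=C=S)C3)c(F)c2)cc1F`, 14.6 nM;
compound 2, `CC(C)c1ccc(-c2ccc(CO[C@H]3C[C@@H](N=C=S)C3)c(F)c2)cc1F`, 227 nM;
compound 3, `COc1ccc(-c2ccc(CO[C@H]3C[C@@H](N=C=S)C3)c(F)c2)cc1OC`, 58.9 nM.

These three compounds were tested in an assay on isolated protein for inhibition of N-acylethanolamine-hydrolyzing acid amidase (Homo sapiens), read by fluorescence, with a stated time of 90 min; a higher number here means a weaker inhibitor, a lower number a stronger inhibitor. Among them, compound 3 stands in the middle: its number is lower than that of compound 2 and higher than that of compound 1, and both of those gaps lie beyond the usual scatter of this assay. Compound 3 is therefore a clearly stronger inhibitor than compound 2 and a clearly weaker one than compound 1.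

Compound 4, `COc1ccc(-c2ccc(CO[C@H]3C[C@@H](N=C=S)C3)c(F)c2)cc1F`, has not yet been measured. It differs from compound 3 in a single place: fluoro in place of methoxy on an aromatic carbon. Within the data shown here, no pair of measured compounds shows exactly this exchange, so the size of the step cannot be read off directly; compound 1 and compound 2 each differ from compound 4 in more than one place. The expected step from compound 3 to compound 4 is a 1.4-fold lower number from compound 3 to compound 4 (0.15 log units; within the scatter), a modest shift toward a lower number that may well stay within the scatter. The estimate for compound 4 in this assay is 42 nM, with a range from 14 nM to 130 nM.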

Compound 4, half-maximal inhibitory concentration: 20.6 nM
Compound 4: middle estimate off by 2.0-fold (0.31 log units), on the high side, and the stated range covers the measured number.
By their numbers in this assay, from the lowest: compounds 1 and 4 (each within the scatter of the next); then compound 3; then compound 2.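

In this assay, fluoro in place of methoxy on this aromatic carbon, ortho to a methoxy group, gives a 2.9-fold lower number from compound 3 to compound 4 (0.46 log units; beyond the scatter), so this place responds to the exchange by more than the scatter and fluoro is well accepted there. The other two steps separate the contributions of two further places: methoxy in place of isopropyl gives an 11-fold lower number from compound 2 to compound 4 (1.04 log units; beyond the scatter), a far larger step, whereas hydrogen in place of methyl on the chain carbon gives a 1.4-fold higher number from compound 1 to compound 4 (0.15 log units; within the scatter), so that methyl makes no readable difference. No measurement at hand explains any of these steps.

The compounds shown leave open how chloro, hydroxyl or an amine would behave on this aromatic carbon. They also leave open whether ethoxy or a longer chain would be accepted where methoxy and isopropyl differ so sharply.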